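Swapping Bromo for Chloro on the Aniline Ring

A few compounds are considered here, and "the series" means these few. Any claim that something is new, unique, unknown or untested is made for them only; others in the source may bear on it.

In a functional assay on NCI-H1975 cells (Homo sapiens) for antiproliferative activity, read by MTT assay, with a stated time of 72 h (a lower number here means a stronger inhibitor, a higher number a weaker inhibitor), three compounds have been measured. Compound 1, `COc1cc2ncnc(Nc3cccc(F)c3)c2cc1OCCCCC(=O)Nc1ccc(S(N)(=O)=O)cc1`, reaches only the limit of the assay, reported as > 40000 nM, so no number is known for it (the limit of > 40000 nM in this assay, at which 1 of the 3 values shown sits). Compound 2, `NS(=O)(=O)c1ccc(NC(=S)Nc2ccc3ncnc(Nc4cccc(C(F)(F)F)c4)c3c2)cc1`, gives 7590 nM. Compound 3, `NS(=O)(=O)c1ccc(NC(=S)Nc2ccc3ncnc(Nc4cccc(Br)c4)c3c2)cc1`, gives 11000 nM. The two numbered values lie close together: a 1.4-fold higher number from compound 2 to compound 3 (0.16 log units; within the scatter), so compound 2 and compound 3 cannot be told apart in potency, and compound 3 stands beside compound 2 with compound 1 known only as a limit.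

Compound 4, `NS(=O)(=O)c1ccc(NC(=S)Nc2ccc3ncnc(Nc4cccc(Cl)c4)c3c2)cc1`, differs from compound 3 in one place: chloro in place of bromo on an aromatic carbon. Within the data shown here, the only measured step that bears on this is the swap at the same position between compound 2 and compound 3, which changed the number by a 1.4-fold higher number from compound 2 to compound 3 (0.16 log units; within the scatter), a step within the scatter. On that basis the change from bromo to chloro is expected to shift the number by a 1.1-fold lower number from compound 3 to compound 4 (0.04 log units; within the scatter), that is, no step beyond the scatter in either direction. For compound 4 the value in this assay is therefore estimated at 10000 nM, with a likely range from 4000 nM to 25000 nM.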

Compound 4, half-maximal inhibitory concentration: 39800 nM
For compound 4 the middle estimate is 4.0-fold (0.60 log units) below the measured one, outside the stated range (above it).
By their numbers in this assay, from the lowest: compounds 2 and 3 (each within the scatter of the next); then compound 4. At a limit, above all of these: compound 1.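

Until now this position had shown only a step within the scatter, but in this assay the change from 3-bromophenyl to 3-chlorophenyl gives a 3.6-fold higher number from compound 3 to compound 4 (0.56 log units; beyond the scatter). One halogen atom replacing another, with the heavy-atom count, hydrogen-bond donors, hydrogen-bond acceptors and net charge all unchanged, is therefore enough to give a clearly weaker inhibitor on this core. Chloro also separates from trifluoromethyl, with a 5.2-fold higher number from compound 2 to compound 4 (0.72 log units; beyond the scatter), so among these three groups, chloro gives the weakest result, while bromo and trifluoromethyl cannot be told apart; compound 4 also lies close to the top of the reported range, where the numbers end in a limit: the limit of > 40000 nM in this assay, at which 1 of the 4 values shown sits.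

The numbers give no measured property that explains why chloro and bromo part here, so the reason for the step stays unknown. Also open, going by these compounds, is how other groups would fare at this same position on this core, such as a methoxy group, an amine or a carboxylic acid, and whether any of them would give a number clearly lower than those of compound 2 and compound 3.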